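This account rests on a few compounds, and the source may have more. Where it says the series, first, only, none or still open, it means among the compounds named here.

Measured so far:
compound 1 `C=C[C@@](C)(/C=C/c1ccc(OC(=O)CC)cc1)CCC=C(C)C` at 23%
compound 2 `C=C[C@@](C)(/C=C/c1ccc(OC(=O)CCCCC)cc1)CCC=C(C)C` at 18%
compound 3 `CC[C@](C)(CCCC(C)C)CCc1ccc(O)c(I)c1` at 40%

All three numbers come from a functional assay on MCF7 cells (Homo sapiens) for inhibition, with a stated time of 48 h, tested at 50 uM (on this read-out higher numbers stand for more inhibition of growth at the one concentration tested and lower numbers for less inhibition of growth), and are compared on that read-out. Compound 3 stands highest at 40% and its gaps to the other two both lie beyond the scatter.

Next in line is compound 4 `CC[C@](C)(CCCC(C)C)CCc1ccc(O)cc1` and the change to it is hydrogen in place of iodo on an aromatic carbon with hydrogen in place of iodo on an aromatic carbon, ortho to a hydroxy group.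

Among the compounds with values here, the only measured step, a number 5 percentage points lower from compound 1 to compound 2 (within the scatter) on a saturated chain carbon, sits at another place and is a different kind of change, so it gives no real guide to size. Within the data shown here, no measured pair shows the loss of iodo. Compound 1 and compound 2 differ from compound 3 in more than one place, so their gaps cannot be credited to iodo alone.

A downward direction is only a tentative expectation, resting on compound 3 at 40% being the top number of the three. The estimated step is a number 9 percentage points lower from compound 3 to compound 4 (within the scatter) in this assay and it carries wide uncertainty. Compound 4 is expected at 31% with an estimated range from 15% to 48% as the working figure.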

Compound 4, percent growth inhibition at one concentration: 46%
For compound 4 the middle estimate is 15 percentage points below the measured one; measured number inside the range.
By their numbers in this assay, from the lowest: compounds 2 and 1 (each within the scatter of the next); then compounds 3 and 4 (each within the scatter of the next).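

In this assay, within the data shown here, the exchange of iodo for hydrogen on the aromatic carbon ortho to a hydroxy group gives a number 6 percentage points higher from compound 3 to compound 4 (within the scatter) and is the first measured pair that isolates this position. The inhibition of growth at the one concentration tested therefore does not depend on iodo in this pair, and on this read-out the iodo and hydrogen forms cannot be told apart at this aromatic carbon. No measurement that could explain this result is at hand.

As far as these compounds go, whether a smaller halogen such as chloro or bromo, a methoxy group or an amine on the same aromatic carbon would also stay within the scatter of compound 3 and compound 4 remains open. Compound 1 and compound 2 differ from compound 4 in more than one place, so the separate contributions of the free hydroxy group against an ester, and of the saturated chain against the unsaturated one, remain unresolved.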